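This account rests on a few compounds, and the source may have more. Where it says the series, first, only, none or still open, it means among the compounds named here.

Compound 1 `C#CCN(C)CCCOc1ccc2c(c1)OCCC2=O` and compound 2 `C#CCN(C)CCCCOc1ccc2c(c1)OCCC2=O` share one core, while compound 3 `C#CCN(C)CCCCCOc1ccc(C=O)c(OC)c1` and compound 4 `C#CCN(C)CCCCCCOc1ccc(C=O)c(OC)c1` share another; the difference between the two cores is not broken down here. In an assay on BTI cells for inhibition of Amine oxidase [flavin-containing] B (Homo sapiens), read by fluorescence and Amplex Red, with a stated time of 15 min (on this read-out higher numbers stand for weaker inhibition and lower numbers for stronger inhibition), compound 1 gives 11400 nM, compound 2 gives 58.9 nM and compound 3 gives 5740 nM. The change (methyl(propargyl)amino)methyl in place of methyl(propargyl)amino on a saturated chain carbon, three bonds along the chain from an oxygen on an aromatic ring produced a 190-fold lower number from compound 1 to compound 2 (2.29 log units; beyond the scatter). The change (methyl(propargyl)amino)methyl in place of methyl(propargyl)amino on a saturated chain carbon, five bonds along the chain from an oxygen on an aromatic ring is the same kind of change, but its place is five bonds along the chain from the aromatic oxygen rather than three, and it sits on a different core. A gain is expected for compound 4, estimated at a 9.6-fold lower number from compound 3 to compound 4 (0.98 log units; beyond the scatter), smaller than the earlier step because compound 3 already carries the longer chain and starts from 5740 nM. Compound 4 is expected to give 600 nM in this assay, between 100 nM and 4000 nM.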

Compound 4, half-maximal inhibitory concentration: 552 nM
Compound 4: the middle estimate sits 1.1-fold (0.04 log units) above what was measured; low and high end bracket the measured number.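

Changing methyl(propargyl)amino to (methyl(propargyl)amino)methyl again lowers the number in this assay, with a 10-fold lower number from compound 3 to compound 4 (1.02 log units; beyond the scatter), so the direction of the change carries over from the core of compound 1 to the core of compound 3. The size of the change does not carry over: the same change on two cores in this assay, a 190-fold lower number (2.29 log units; beyond the scatter) from compound 1 to compound 2 and a 10-fold lower number (1.02 log units; beyond the scatter) from compound 3 to compound 4, 19-fold (1.27 log units) apart, beyond the scatter of two such steps

These two pairs also differ in where the change sits along the chain, so they cannot show whether the core or that position sets the size of the gain. The compounds shown leave open whether a longer chain would lower the number further on either core. Also open, on these data alone, is how a dimethylamino group would compare with the methyl(propargyl)amino group at the chain end.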